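The compounds below may be only part of what the source reports. "The series", "measured", "known", "first", "only" and "open" are said of these compounds alone.

Compound 1, `CCCCCc1cn([C@H]2C[C@H](O)[C@@H](CO)O2)c(=O)[nH]c1=O`: in a functional assay on Raji cells (Homo sapiens) (on this read-out lower numbers stand for stronger inhibition and higher numbers for weaker inhibition), compound 1 gives 328 ug/mL.
Compound 2, `CC(C)c1cn([C@H]2C[C@@H]3OP(=O)(O)OC[C@H]3O2)c(=O)[nH]c1=O`: compound 2 gives only a limit of the assay, > 500 ug/mL.
Compound 3, `CCCCCc1cn([C@H]2C[C@@H]3OP(=O)(O)OC[C@H]3O2)c(=O)[nH]c1=O`: compound 3 gives only a limit of the assay, > 500 ug/mL.

For the measured compounds named here, compound 1 therefore stands as the only true number among the three values; the other two are limits. Going by the values given here, the single step between measured compounds, a step that the two limits leave unreadable from compound 2 to compound 3, cannot be read in size because both of its values sit at the limit of > 500 ug/mL in this assay, at which 2 of the 3 values shown sit.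

Compound 4, `CCCCCCCCc1cn([C@H]2C[C@H](O)[C@@H](CO)O2)c(=O)[nH]c1=O`, differs from compound 1 by propyl in place of hydrogen on a saturated chain carbon, five bonds along the chain from an aromatic carbon. Among the compounds with values here, the one measured step, from compound 2 to compound 3, also lengthens a chain on an aromatic carbon, but it tells nothing about direction or size. No readable step bears on the change from compound 1 to compound 4, so the expected step is set near zero, as a 1.1-fold lower number from compound 1 to compound 4 (0.04 log units; within the scatter) in this assay. Compound 4 is therefore estimated at 300 ug/mL, with a range from 80 ug/mL to 600 ug/mL.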

Compound 4, concentration for 50% inhibition: 140 ug/mL
Compound 4: middle estimate off by 2.1-fold (0.33 log units), on the high side; the measured number falls inside the stated range.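

In this assay, propyl in place of hydrogen on a saturated chain carbon, five bonds along the chain from an aromatic carbon, gives a 2.3-fold lower number from compound 1 to compound 4 (0.37 log units; beyond the scatter). For the compounds shown here, this is the first readable step in the set, and it shows that extending the chain at this position moves the number towards stronger inhibition, though only modestly. The earlier chain change on the core of compound 3 could not show this, because neither of its two values is a true number: the limit of > 500 ug/mL in this assay, at which 2 of the 4 values shown sit.

Going by these compounds, a single pair gives a direction for this one change, not a trend, so whether a longer chain would lower the number further remains open. Also open, on these data alone, is what an amine or a carboxylic acid at the end of the chain would do in place of the added carbons.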